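Replacing a fluoropyridyl group with a pyridone: permeability outlook

The source may hold more compounds than are shown below. What is called first, only, known or untested is meant among the compounds shown, and "the series" means these compounds.

Compound 3 `CCCCc1nc(=O)c(S(=O)(=O)c2ccc(-c3ccc(F)nc3)cc2)c(O)n1-c1c(OC)cccc1OC` gives 516 nm/s in an ADME assay for permeability, using PAMPA, at pH 5.5 (on this read-out lower numbers stand for lower permeability and higher numbers for higher permeability), the highest of the three numbers measured; compound 1 `CCCCc1nc(=O)c(S(=O)(=O)c2ccc(-c3ccc(F)cc3)cc2)c(O)n1-c1c(OC)cccc1OC` gives 418 nm/s, and compound 2 `CCCCc1nc(=O)c(S(=O)(=O)c2ccc(-c3cccnc3)cc2)c(O)n1-c1c(OC)cccc1OC` gives 202 nm/s. Compound 4 `CCCCc1nc(=O)c(S(=O)(=O)c2ccc(-n3ccccc3=O)cc2)c(O)n1-c1c(OC)cccc1OC` differs from compound 3 by a group of 7 heavy atoms (5 carbon, 1 nitrogen, 1 oxygen; one six-membered aromatic ring with 1 hetero atom) in place of a group of 7 heavy atoms (5 carbon, 1 nitrogen, 1 fluorine; one six-membered aromatic ring with 1 hetero atom), on an aromatic carbon, so a group with 1 hydrogen-bond acceptor gives way to one with 2 hydrogen-bond acceptors and 1 double bond outside aromatic rings. Within the data shown here, two measured steps bear on this: a 2.1-fold lower number from compound 1 to compound 2 (0.32 log units; beyond the scatter), and a 2.6-fold higher number from compound 2 to compound 3 (0.41 log units; beyond the scatter). Both show that swapping the ring at this position moves this assay by a modest amount, and the loss of the fluoro atom in particular went with the lower number. Because a 2.6-fold higher number from compound 2 to compound 3 (0.41 log units; beyond the scatter) went with adding the fluoro atom, and the entering group of compound 4 drops that fluoro atom and gains an acceptor, a downward step in this assay is expected for compound 4, likely at least as large as the modest steps seen so far. The estimated step is a 4.7-fold lower number from compound 3 to compound 4 (0.67 log units; beyond the scatter). Compound 4 is therefore expected to give 110 nm/s, within a range from 35 nm/s to 300 nm/s.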

Compound 4, apparent permeability: 12 nm/s
Compound 4: middle estimate off by 9.2-fold (0.96 log units), on the high side; measured number below the stated range.
By their numbers in this assay, from the lowest: compound 4; then compound 2; then compounds 1 and 3 (each within the scatter of the next).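

In this assay, among these compounds, this position proves far more sensitive than the earlier compounds showed: 4-fluorophenyl, pyridin-3-yl and 6-fluoropyridin-3-yl differ only by modest steps or within the scatter, whereas the pyridone group brings a 43-fold lower number from compound 3 to compound 4 (1.63 log units; beyond the scatter). The missing fluoro atom does not cover the size of this fall, as the fluorine-free pyridin-3-yl group also gives way to a large step, a 17-fold lower number from compound 2 to compound 4 (1.23 log units; beyond the scatter), and the change from the carbon-only ring is of similar scale, a 35-fold lower number from compound 1 to compound 4 (1.54 log units; beyond the scatter). Nothing in the data shown explains why the pyridone group stands so far apart. As far as these compounds go, it remains open whether the fall follows from the ring carbonyl itself or from the way the ring is attached. Also open, from the compounds shown here alone, is how a morpholine or a methoxypyridine on this aromatic carbon would read.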